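Swapping imidazole for piperazine on a shared core

A few compounds are considered here, and "the series" means these few. Any claim that something is new, unique, unknown or untested is made for them only; others in the source may bear on it.

The series rests on one shared core carried by compound 1 `COc1ccc2nccc(NC(c3cccc(Cl)c3)c3ccc(CN4CCCC4)c(Cl)c3)c2c1`, compound 2 `Clc1cccc(C(Nc2ccnc3cc(Cl)ccc23)c2ccc(CN3CCCC3)cc2)c1` and compound 3 `Clc1ccc(C(Nc2ccnc3cc(Cl)ccc23)c2ccc(Cn3ccnc3)cc2)cc1`. In an ADME assay on NIH3T3 cells (Mus musculus) for cytotoxicity, read by neutral red uptake, with a stated time of 24 h (on this read-out higher numbers stand for lower toxicity in this test and lower numbers for higher toxicity in this test), compound 1 gives 24 uM, compound 2 gives 9 uM and compound 3 gives 35 uM. Compound 3 and compound 1 sit within the usual scatter of each other, whereas compound 2 lies beyond it with the lower number. Compound 4 `Clc1ccc(C(Nc2ccnc3cc(Cl)ccc23)c2ccc(CN3CCNCC3)cc2)cc1` differs from compound 3 by piperazin-1-yl in place of 1H-imidazol-1-yl on a saturated chain carbon bound to an aromatic carbon. Among the compounds with values here, no step between measured compounds matches this change. In this assay a modest move toward a lower number is expected from compound 3 to compound 4 , a 1.8-fold lower number from compound 3 to compound 4 (0.24 log units; within the scatter), partly because compound 2 gives 9 uM. Compound 4 is therefore estimated at 20 uM, with a range from 7 uM to 50 uM.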

Compound 4, half-maximal toxic concentration: 1.8 uM
The estimate for compound 4 lay 11-fold (1.05 log units) above the measured number, and the stated range ends above it.
By their numbers in this assay, from the lowest: compound 4; then compound 2; then compounds 1 and 3 (each within the scatter of the next).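

In this assay, replacing 1H-imidazol-1-yl with piperazin-1-yl on a saturated chain carbon bound to an aromatic carbon gives a 19-fold lower number from compound 3 to compound 4 (1.29 log units; beyond the scatter), so the number at this position depends strongly on the group it carries. This is the only single-place step shown, and the earlier compounds could not reveal its size. Nothing available explains the size of this step. The compounds shown leave open whether the drop follows the piperazin-1-yl ring as a whole or its ring amine hydrogen, a question that a morpholin-4-yl group or a 4-methylpiperazin-1-yl group at this position would address.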